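Swapping a Thiadiazole for a Pyridine on the Thioether

The source may report more compounds than this note shows. Statements on the series, on what has been measured and on what is new or still open speak of the compounds shown alone.

Compound 1, `C#CCSc1nc(Sc2nnnn2CCN(C)C)c(C#N)c(-c2cccc(Cl)c2)n1`, gives 6480 nM in a functional assay on PC-9 cells (Homo sapiens) for antiproliferative activity, read by MTT assay; a lower number here means a stronger inhibitor, a higher number a weaker inhibitor. Compound 2, `C#CCSc1nc(Sc2nncs2)c(C#N)c(-c2cc(OC)c(OC)c(OC)c2)n1`, gives 7960 nM in this assay. For compound 3, `C#CCSc1nc(Sc2nccs2)c(C#N)c(-c2ccc[nH]2)n1`, the result in this assay is the limit > 20000 nM, not a number; (the limit of > 20000 nM in this assay, at which 1 of the 3 values shown sits).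

Among the two numbers shown, compound 2 sits close to compound 1, and the gap between them lies within the usual scatter of this assay, so neither can be called the stronger inhibitor.

Compound 4, `C#CCSc1nc(Sc2ccccn2)c(C#N)c(-c2cc(OC)c(OC)c(OC)c2)n1`, differs from compound 2 by pyridin-2-yl in place of 1,3,4-thiadiazol-2-yl on a sulfur. Among the measured compounds shown here, no measured pair shows this change, so a step beyond the scatter is not expected in either direction. Compound 4 is expected to give about 8000 nM, somewhere between 2500 nM and 24000 nM. That estimate means an expected step of a 1.0-fold higher number from compound 2 to compound 4 (0.00 log units; within the scatter).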

Compound 4, half-maximal inhibitory concentration: > 20000 nM
Compound 4 ended at the assay's limit; the forecaster's own chance of this, stated with the estimate: 15%; middle value at least 2.5-fold (0.39 log units) from the limit.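

The group on this sulfur matters for antiproliferative activity. In this assay, among the compounds shown here, pyridin-2-yl in place of 1,3,4-thiadiazol-2-yl brings an at least 2.5-fold higher number from compound 2 to compound 4 (0.40 log units; beyond the scatter) and so gives the first comparison here of compounds that differ in one place. The full size of this step stays unknown, because the result for compound 4 is a limit and not a number: the limit of > 20000 nM in this assay, at which 2 of the 4 values shown sit.

Only these two groups can be compared on an otherwise unchanged compound. As far as these compounds go, it remains open whether a pyrimidin-2-yl ring, a 1,3,4-oxadiazol-2-yl ring or a simple methyl on this sulfur would keep the number close to that of compound 2.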